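Removing bromo from compound 3 to give compound 4

A few compounds are considered here, and "the series" means these few. Any claim that something is new, unique, unknown or untested is made for them only; others in the source may bear on it.

Measured in a physicochemical assay, with a stated time of 6 min; a higher number here means a weaker inhibitor, a lower number a stronger inhibitor:
- compound 1 `O=C(Nc1ccc(Br)cc1)Nc1nc(-c2cc3ccccc3o2)cs1`: > 200000 nM
- compound 2 `O=C(Nc1nc(-c2cc3ccccc3o2)cs1)Nc1ccccc1F`: 2630 nM
- compound 3 `O=C(Nc1ccc([N+](=O)[O-])cc1)Nc1nc(-c2cc3cc(Br)ccc3o2)cs1`: > 200000 nM

Compound 3 stands at the limit of > 200000 nM in this assay, at which 2 of the 3 values shown sit. Its entry is a limit and not a number, so any change from it can only be judged loosely.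

Compound 4 `O=C(Nc1ccc([N+](=O)[O-])cc1)Nc1nc(-c2cc3ccccc3o2)cs1` keeps the nitrophenyl group of compound 3 and carries hydrogen in place of bromo on an aromatic carbon.

For the measured compounds named here, no measured step makes this change. The only one, an at least 76-fold lower number from compound 1 to compound 2 (1.88 log units; beyond the scatter), is large and beyond the scatter, but it alters a different place, the group on an amide-type nitrogen, and so bears on this change only indirectly. Compound 1 also lacks this bromo, and its > 200000 nM is likewise a limit. A small step toward a lower number in this assay is therefore expected, and the reading may stay at the limit. The expected step is an at least 1.6-fold lower number from compound 3 to compound 4 (0.22 log units; that floor lies within the scatter). For compound 4 the estimate is 120000 nM, with an expected range from 15000 nM to 200000 nM.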

Compound 4, half-maximal inhibitory concentration: 19300 nM
Beside the measured number, compound 4's estimate is 6.2-fold (0.79 log units) above it; the measured number falls inside the stated range.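

In this assay, hydrogen in place of bromo on this aromatic carbon gives an at least 10-fold lower number from compound 3 to compound 4 (1.01 log units; beyond the scatter), and compound 4 is the only nitrophenyl compound shown with a number and not a limit. Without the bromo, the group on the amide-type nitrogen also separates the compounds: nitro in place of bromo on the phenyl ring gives an at least 10-fold lower number from compound 1 to compound 4 (1.01 log units; beyond the scatter), while 4-nitrophenyl in place of 2-fluorophenyl gives a 7.3-fold higher number from compound 2 to compound 4 (0.87 log units; beyond the scatter). The steps from compound 1 and compound 3 are floors only, because each starts from a limit: the limit of > 200000 nM in this assay, at which 2 of the 4 values shown sit.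

As far as these compounds go, whether bromo on this aromatic carbon costs as much with 2-fluorophenyl on the amide-type nitrogen stays open. Among the compounds shown this carbon carries only bromo or hydrogen, so an amine or a methoxy group there would test whether anything other than hydrogen keeps a measurable number.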